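A new aryl group on a sulfonyl sulfur

A few compounds are considered here, and "the series" means these few. Any claim that something is new, unique, unknown or untested is made for them only; others in the source may bear on it.

Compound 1 (`COc1ccc(C(=O)Nc2nccc3ncc(-c4cnn(C)c4)cc23)cc1`): (> 50000 nM)
Compound 2 (`Cn1cc(-c2cnc3ccnc(NS(=O)(=O)c4ccc(C(F)(F)F)cc4)c3c2)cn1`): (> 50000 nM)

Both compounds were tested in a functional assay on A549 cells (Homo sapiens) for antiproliferative activity, read by MTT assay, with a stated time of 48 h (on this read-out lower numbers stand for stronger inhibition and higher numbers for weaker inhibition), and neither gave a number. Compound 1 reads (> 50000 nM), which is a limit of the assay. Compound 2 reads (> 50000 nM), which is also a limit. Compound 2 therefore stands with compound 1 at the same boundary (the limit of > 50000 nM in this assay, at which 2 of the 2 values shown sit), and no order can be drawn between them.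

Compound 3 (`Cn1cc(-c2cnc3ccnc(NS(=O)(=O)c4c(Cl)cccc4Cl)c3c2)cn1`) has 2,6-dichlorophenyl in place of 4-(trifluoromethyl)phenyl on a sulfonyl sulfur. Among the compounds with values here, no measured step shows what such a change does. Compound 2 offers only its limit (> 50000 nM), so any visible change in this assay would have to be toward stronger inhibition, and only a modest one is expected. The expected change is (an at least 1.4-fold lower number from compound 2 to compound 3 (0.15 log units; that floor lies within the scatter)). Compound 3 is estimated at (35000 nM), with an expected range from (8000 nM) to (60000 nM).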

Compound 3, half-maximal inhibitory concentration: > 50000 nM
Compound 3 was reported as a limit; the forecaster's own chance of this, stated with the estimate: 65%; middle value at least 1.4-fold (0.15 log units) from the limit.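

Within the data shown here, compound 2 and compound 3 both sit at a limit, so the change from compound 2 to compound 3 gives no step that can be read: (the limit of > 50000 nM in this assay, at which 3 of the 3 values shown sit). Still open, going by these compounds, is whether any aryl group on the sulfonyl sulfur gives a measurable number in this assay on the shared core.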